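The compounds below may be only part of what the source reports. "The series", "measured", "known", "first", "only" and "open" are said of these compounds alone.

Measured compounds in a functional assay on CHO cells for antagonist activity at sphingosine 1-phosphate receptor 2 (Homo sapiens), read by fluorescence and calcium flux, with a stated time of 3 min; on this read-out higher numbers stand for weaker inhibition and lower numbers for stronger inhibition:

Compound 1 `Cc1cc(NNC(=O)Nc2cc(Cl)nc(Cl)c2)ncc1C#N` gives 6000 nM.
Compound 2 `Cc1cc(C#N)nc(NNC(=O)Nc2cc(Cl)nc(Cl)c2)c1` gives > 6600 nM.
Compound 3 `Cc1cc(NNC(=O)Nc2cc(Cl)nc(Cl)c2)ncc1-c1ccn(C)n1` gives 4000 nM.

For compound 2 the value given is a limit of this assay, not a number (the limit of > 6600 nM in this assay, at which 1 of the 3 values shown sits); it stands at the weak end of the values shown. Compound 4 `Cc1cc(NNC(=O)Nc2cc(Cl)nc(Cl)c2)nc(C(=O)N(C)C)c1` carries dimethylcarbamoyl in place of cyano on an aromatic carbon.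

For the measured compounds named here, only one measured step replaces cyano by another group: a 1.5-fold lower number from compound 1 to compound 3 (0.18 log units; within the scatter). Going by the values given here, no step replaces cyano by dimethylcarbamoyl, and none changes the group at the site varied in compound 4, so the evidence bearing on this change is thin. From that single step no shift beyond the scatter is expected in this assay, so the estimated step is a step that the limit leaves unreadable from compound 2 to compound 4. Compound 4 is therefore expected at 8000 nM, with a range from 3000 nM to 20000 nM.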

Compound 4, half-maximal inhibitory concentration: > 19000 nM
Compound 4: only a limit was reported; the forecaster's own chance of this, stated with the estimate: 50%; middle value at least 2.3-fold (0.37 log units) away from the limit.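

In this assay compound 2 and compound 4 both stand at limits of the assay, not numbers, and the step between them cannot be read. The compounds shown leave open how dimethylcarbamoyl compares with cyano on this aromatic carbon, next to the ring nitrogen.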